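The compounds below may be only part of what the source reports. "The series", "measured", "known", "first", "only" and "open" are said of these compounds alone.

Compound 1 `O=c1cc(-c2ccc([N+](=O)[O-])cc2)oc2cc(O)ccc12` is the starting point of this small series. In a functional assay on HT-29 cells (Homo sapiens) for cytotoxicity, read by MTT assay, with a stated time of 6 days (on this read-out higher numbers stand for an effect only at larger amounts of compound and lower numbers for an effect already at smaller amounts), compound 1 gives 6.95 ug/mL. Compound 2 `O=c1cc(-c2ccc([N+](=O)[O-])cc2)oc2c(O)c(O)ccc12` carries one change against compound 1, namely (hydroxy in place of hydrogen on an aromatic carbon). In this assay compound 2 gives 3.46 ug/mL. That change made a 2.0-fold lower number from compound 1 to compound 2 (0.30 log units; within the scatter), so the two values cannot be told apart by this read-out.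

Compound 3 `COc1cc(-c2cc(=O)c3ccc(O)cc3o2)cc(OC)c1OC` is built on a different core from compound 1; the difference between the two cores is not broken down here. In this assay compound 3 gives only a limit, > 25 ug/mL, and no number. This is the limit of > 25 ug/mL in this assay, at which 1 of the 3 values shown sits.

Compound 4 `COc1cc(-c2cc(=O)c3ccc(O)c(O)c3o2)cc(OC)c1OC` has not yet been measured. It stands to compound 3 as compound 2 stands to compound 1: the change is hydroxy in place of hydrogen on an aromatic carbon, and the surroundings of the place match those of the earlier change word for word, so it is the same change made a second time.

What that change did once is known: compound 2 against compound 1 gave a 2.0-fold lower number from compound 1 to compound 2 (0.30 log units; within the scatter), a step that does not leave the scatter. Compound 4 is therefore expected to show a step of about a number no higher from compound 3 to compound 4 (the limit leaves the size open), resting on that earlier step and on the fact that compound 3 sits at the limit (the limit of > 25 ug/mL in this assay, at which 1 of the 3 values shown sits). Compound 4 is estimated at 25 ug/mL in this assay, with a likely range from 10 ug/mL to 60 ug/mL, and it may well again be reported only as a limit.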

Compound 4, concentration for half-maximal effect: 3.66 ug/mL
Compound 4: middle estimate off by 6.8-fold (0.83 log units), on the high side, outside the stated range (below it).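

In this assay, hydroxy in place of hydrogen on an aromatic carbon did not carry over from one core to the other at the same size, for the new case gave an at least 6.8-fold lower number from compound 3 to compound 4 (0.83 log units; beyond the scatter). Set beside the earlier case, the two steps differ by more than the scatter: the same change on two cores in this assay, a 2.0-fold lower number (0.30 log units; within the scatter) from compound 1 to compound 2 and an at least 6.8-fold lower number (0.83 log units; beyond the scatter) from compound 3 to compound 4, at least 3.4-fold (0.53 log units) apart, beyond the scatter of two such steps. This shows that, in these two pairs, the size of the step on the core of compound 1 did not predict its size on the core of compound 3, but it rests on only two pairs, gives no reason for the gap, and fixes only a lower bound for the new step, as compound 3 has a limit and not a number: the limit of > 25 ug/mL in this assay, at which 1 of the 4 values shown sits.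

The compounds shown leave open which part of the difference between the two cores goes with the larger step, as no pair separates the parts of that difference from one another. They also leave open whether an amine or a carboxylic acid entering at the same place, ortho to a hydroxy group, would give steps that differ between the two cores in the same way.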